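Trading a triazole tail for a short amide

A few compounds are considered here, and "the series" means these few. Any claim that something is new, unique, unknown or untested is made for them only; others in the source may bear on it.

In an assay for inhibition of RAC-alpha serine/threonine-protein kinase (Homo sapiens), read by HTRF, with a stated time of 1 h (on this read-out higher numbers stand for weaker inhibition and lower numbers for stronger inhibition), compound 2 `Cn1ncc(Cl)c1-c1cc(C(=O)N[C@@H]2CN[C@H](CCn3cncn3)C[C@H]2c2ccc(Cl)c(Cl)c2)oc1Cl` gives 4.47 nM, the higher of the two numbers measured, yet within the scatter of compound 1 `Cn1ncc(Cl)c1-c1cc(C(=O)N[C@@H]2CN[C@H](CCCO)C[C@H]2c2ccc(Cl)c(Cl)c2)oc1Cl`, which gives 2.56 nM. For the measured compounds named here, the single measured step, a 1.7-fold higher number from compound 1 to compound 2 (0.24 log units; within the scatter), altered the end of this same side chain and stayed within the scatter. Compound 3 `Cn1ncc(Cl)c1-c1cc(C(=O)N[C@@H]2CN[C@H](CC(N)=O)C[C@H]2c2ccc(Cl)c(Cl)c2)oc1Cl` differs from compound 2 by carbamoyl in place of (1H-1,2,4-triazol-1-yl)methyl on a saturated chain carbon bound to a saturated ring carbon. Because the earlier change on this chain, a 1.7-fold higher number from compound 1 to compound 2 (0.24 log units; within the scatter), lay within the scatter, no step beyond the scatter is expected here either. Compound 3 is therefore estimated at 4.5 nM, between 1.5 nM and 14 nM, meaning an expected step of a 1.0-fold higher number from compound 2 to compound 3 (0.00 log units; within the scatter).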

Compound 3, half-maximal inhibitory concentration: 3.24 nM
Compound 3: middle estimate off by 1.4-fold (0.14 log units), on the high side; the range from low to high includes it.
By their numbers in this assay, from the lowest: compounds 1, 3 and 2 (each within the scatter of the next).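

Replacing the (1H-1,2,4-triazol-1-yl)methyl group with carbamoyl removes the aromatic ring and leaves a much smaller group, yet the result is a 1.4-fold lower number from compound 2 to compound 3 (0.14 log units; within the scatter). Comparing the same short amide with the 2-hydroxyethyl group gives a 1.3-fold higher number from compound 1 to compound 3 (0.10 log units; within the scatter), so the alcohol, triazole and amide ends on this chain all sit within the scatter of one another. No evidence here explains why these different ends read alike. From the compounds shown here alone, it remains open whether an amine, a carboxylic acid or a longer chain at this position would also stay within the scatter.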